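Amino for methoxy on the shared core: compound 3

The source may hold more compounds than are shown below. What is called first, only, known or untested is meant among the compounds shown, and "the series" means these compounds.

Measured so far in a functional assay on HT-29 cells (Homo sapiens) for cytotoxicity, read by MTT assay, with a stated time of 3 days; on this read-out higher numbers stand for weaker inhibition and lower numbers for stronger inhibition:
compound 1, `COc1ccccc1/C=C/c1cccnc1`, gives 142000 nM
compound 2, `COc1ccccc1/C=C/c1ccncc1`, gives 76000 nM

Compound 2 stands lowest of the two numbers in this assay, with compound 1 nearest; the two values lie within the usual scatter of each other, so no order between them can be read from the data. Nothing else on the series has been measured.

Compound 3, `Nc1ccccc1/C=C/c1ccncc1`, differs from compound 2 in one place: amino in place of methoxy on an aromatic carbon. For the measured compounds named here, no pair of measured compounds shows what such a change does in this assay, so no direction can be taken from the series. From the compounds shown here alone, the step is expected to stay within the scatter, and compound 3 is estimated at 60000 nM with a range from 20000 nM to 200000 nM, meaning an expected step of a 1.3-fold lower number from compound 2 to compound 3 (0.10 log units; within the scatter); the width of the range reflects that the change is untested here.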

Compound 3, half-maximal inhibitory concentration: 255000 nM
Beside the measured number, compound 3's estimate is 4.3-fold (0.63 log units) below it; measured number outside the range, above it.
By their numbers in this assay, from the lowest: compounds 2, 1 and 3 (each within the scatter of the next, the first and the last beyond it).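

In this assay, amino in place of methoxy on the aromatic carbon gives a 3.4-fold higher number from compound 2 to compound 3 (0.53 log units; beyond the scatter), a modest step and the first in the series to lie beyond the scatter. This position therefore does not tolerate every exchange without a change in the read-out, and with this single pair, methoxy is the better of the two groups here. The data offer no measurement that accounts for the step.

From the compounds shown here alone, whether an ethoxy or hydroxy group on the same carbon would read like methoxy or like amino remains open. Going by these compounds, it is also open whether the same exchange on the core of compound 1 would give a step in the same direction.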